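Halogen-to-methyl swap on the benzoyl ring in a coumarin hydrazide series

The compounds below may be only part of what the source reports. "The series", "measured", "known", "first", "only" and "open" are said of these compounds alone.

Measured so far in a functional assay on DLA cells (Mus musculus) for cytotoxicity, read by trypan blue exclusion, with a stated time of 48 h; a lower number here means a stronger inhibitor, a higher number a weaker inhibitor:
- compound 1, `Cc1ccc(OCC(=O)NNC(=O)c2cc3ccccc3oc2=O)c(C(=O)c2cccc(Cl)c2)c1`, gives 68600 nM
- compound 2, `Cc1ccc(OCC(=O)NNC(=O)c2cc3ccccc3oc2=O)c(C(=O)c2ccc(Cl)cc2)c1`, gives 61600 nM
- compound 3, `Cc1ccc(OCC(=O)NNC(=O)c2cc3ccccc3oc2=O)c(C(=O)c2ccc(Br)cc2)c1`, gives 95500 nM

Compound 3 carries the highest of the three numbers, but its steps to the others are within the scatter: a 1.4-fold higher number from compound 1 to compound 3 (0.14 log units; within the scatter) and a 1.6-fold higher number from compound 2 to compound 3 (0.19 log units; within the scatter). Compound 4, `Cc1ccc(C(=O)c2cc(C)ccc2OCC(=O)NNC(=O)c2cc3ccccc3oc2=O)cc1`, is obtained by the change (methyl in place of bromo on an aromatic carbon). Among the measured compounds shown here, no measured step exchanges a halogen for a methyl; the steps that bear on the same position, a 1.1-fold lower number from compound 1 to compound 2 (0.05 log units; within the scatter) and a 1.6-fold higher number from compound 2 to compound 3 (0.19 log units; within the scatter), are all within the scatter. Compound 4 is therefore expected to show no step beyond the scatter in this assay, a 1.2-fold lower number from compound 3 to compound 4 (0.08 log units; within the scatter). The estimate for compound 4 is 80000 nM, with a range of 40000 nM to 160000 nM.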

Compound 4, half-maximal inhibitory concentration: 87300 nM
Estimate against measurement, compound 4: 1.1-fold (0.04 log units) below, and the stated range covers the measured number.
By their numbers in this assay, from the lowest: compounds 2, 1, 4 and 3 (each within the scatter of the next).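

The position on the benzoyl ring now has a measured exchange of halogen for methyl in this assay: methyl in place of bromo (a step of a 1.1-fold lower number from compound 3 to compound 4 (0.04 log units; within the scatter)) and methyl in place of chloro (a step of a 1.4-fold higher number from compound 2 to compound 4 (0.15 log units; within the scatter)) both stay within the scatter. The comparison with the 3-chlorophenyl compound (a step of a 1.3-fold higher number from compound 1 to compound 4 (0.10 log units; within the scatter)) is also within the scatter. No available evidence explains this lack of separation.

Open, as far as these compounds go, is whether this position responds to any group at all. An amine, a carboxylic acid or a longer chain in place of methyl would test that.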